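This account rests on a few compounds, and the source may have more. Where it says the series, first, only, none or still open, it means among the compounds named here.

Notes on the series around the shared core: compound 1 `Cc1ccc2cc(CN(Cc3ccc(Cl)cc3)Cc3ccc(C(C)C)cc3)c(=O)[nH]c2c1`, compound 2 `Cc1cccc2cc(CN(Cc3ccc(F)cc3)Cc3ccc(C(C)(C)C)cc3)c(=O)[nH]c12` and compound 3 `COc1ccc(CN(Cc2ccc(C(C)(C)C)cc2)Cc2cc3cc(C)ccc3[nH]c2=O)cc1` have been run in a toxicity assay on MDCK cells (Canis lupus familiaris) for cytotoxicity, read by crystal violet staining, with a stated time of 48 h; on this read-out higher numbers stand for lower toxicity in this test and lower numbers for higher toxicity in this test. Compound 1 returns only a limit of the test, > 33000 nM. For compound 2 the entry reads "not determined" (no result reported). Compound 3 likewise returns a limit, > 10000 nM, so compound 3 stands among the entries without a single number, one sitting at the limit of > 10000 nM in this assay, at which 1 of the 3 values shown sits, and one at the limit of > 33000 nM in this assay, at which 1 of the 3 values shown sits. Compound 4 `Cc1ccc2[nH]c(=O)c(CN(Cc3ccc(C(C)(C)C)cc3)[C@H](C)c3ccc(F)cc3)cc2c1` differs from compound 3 by 1-(4-fluorophenyl)ethyl in place of 4-methoxybenzyl on an amine nitrogen. Among the compounds with values here, no measured step exists to lean on; the change is expected to move this assay by nothing beyond the scatter, and a step that the limit leaves unreadable from compound 3 to compound 4 is expected to be close to flat. Compound 4 is therefore estimated at 25000 nM, within 8000 nM to 70000 nM.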

Compound 4, half-maximal cytotoxic concentration: > 5000 nM
Compound 4 ended at the assay's limit (the forecaster's own chance of this, stated with the estimate: 70%); the middle value lies beyond the limit too.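

Compound 3 and compound 4 both give only limits in this assay, so the step between them cannot be read. The compounds shown leave open how far any change around the shared core moves this assay.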